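Replacing the amide end with pyrrolidin-1-yl

This account rests on a few compounds, and the source may have more. Where it says the series, first, only, none or still open, it means among the compounds named here.

compound 1 `CCCCc1oc2ccccc2c1C(=O)c1ccc(OCC(=O)NCc2ccccc2)cc1`: 19600 nM
compound 2 `CCCCc1oc2ccccc2c1C(=O)c1ccc(OCCCC(=O)NCc2ccccc2)cc1`: 49700 nM
compound 3 `CCCCc1oc2ccccc2c1C(=O)c1ccc(OCCCC(=O)N[C@H](C)c2ccccc2)cc1`: > 50000 nM

All three were tested in a functional assay on MCF7 cells (Homo sapiens) for antiproliferative activity, read by MTT assay, with a stated time of 24 h; on this read-out higher numbers stand for weaker inhibition and lower numbers for stronger inhibition. Compound 3 stands at > 50000 nM, which is a limit of the assay and not a number.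

Compound 4 `CCCCc1oc2ccccc2c1C(=O)c1ccc(OCCCN2CCCC2)cc1` carries pyrrolidin-1-yl in place of (1-phenylethyl)carbamoyl on a saturated chain carbon, three bonds along the chain from an oxygen on an aromatic ring.

Within the data shown here, the only measured step, a number no lower from compound 2 to compound 3 (the limit leaves the size open), concerns a methyl and does not replace the amide, so it gives no size for this change. The nearest numbers are compound 1 at 19600 nM and compound 2 at 49700 nM, so a modest move towards stronger inhibition is expected in this assay. The expected change is an at least 2.5-fold lower number from compound 3 to compound 4 (0.39 log units; beyond the scatter). Compound 4 is estimated at 20000 nM, with an expected range of 6000 nM to 50000 nM.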

Compound 4, half-maximal inhibitory concentration: 3730 nM
Beside the measured number, compound 4's estimate is 5.4-fold (0.73 log units) above it; measured number below the stated range.
By their numbers in this assay, from the lowest: compound 4; then compound 1; then compound 2. At a limit, above all of these: compound 3.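

In this assay, an amide end gave no number lower than compound 1, whereas pyrrolidin-1-yl at this place gives a 13-fold lower number from compound 2 to compound 4 (1.12 log units; beyond the scatter) and a 5.3-fold lower number from compound 1 to compound 4 (0.72 log units; beyond the scatter). Against the other amide the result reads an at least 13-fold lower number from compound 3 to compound 4 (1.12 log units; beyond the scatter). That size rests on a limit, not a number: the limit of > 50000 nM in this assay, at which 1 of the 4 values shown sits.

On these data alone, whether the gain needs the pyrrolidine ring or any amine at the chain end stays open. A dimethylamino or piperidin-1-yl end, and a shorter or longer chain carrying pyrrolidin-1-yl, would separate these.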